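This account rests on a few compounds, and the source may have more. Where it says the series, first, only, none or still open, it means among the compounds named here.

Compound 1 `COc1ccc(-c2nnsc2SCC(=O)Nc2ccccc2Cl)cc1`: in an ADME assay on MT4 cells (Homo sapiens) for cytotoxicity (a higher number here means that more compound is tolerated, a lower number that less compound is tolerated), compound 1 gives > 318000 nM, which is a limit of the assay and not a number.
Compound 2 `COc1ccc(-c2nnsc2SCC(=O)Nc2ccccc2Br)cc1`: in this assay compound 2 gives > 286000 nM, again a limit of the assay.
Compound 3 `CCOC(=O)c1ccc(NC(=O)CSc2snnc2-c2ccc(OC)cc2)c(Br)c1`: in this assay compound 3 gives > 245000 nM, also a limit of the assay.

Compound 2 therefore stands where every measured member of the series stands so far: at a limit, with no numbered value anywhere in this assay to place it against.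

Compound 4 `O=C(CSc1snnc1-c1ccc(Cl)cc1Cl)Nc1ccccc1Br` differs from compound 2 by 2,4-dichlorophenyl in place of 4-methoxyphenyl on an aromatic carbon. Among the compounds with values here, two measured steps touch the series, a step that the two limits leave unreadable from compound 1 to compound 2 and a step that the two limits leave unreadable from compound 2 to compound 3, and neither can be read, because each end sits at a limit such as the limit of > 286000 nM in this assay, at which 1 of the 3 values shown sits. Within the data shown here, both steps change the anilide part; no measured step changes the aryl group on the core, so the change in compound 4 rests on no direct precedent.

With every value at a limit, no step beyond the scatter is expected in this assay. Compound 4 is estimated at 250000 nM, within 60000 nM to 400000 nM. The step from compound 2 to compound 4 is expected to be an at least 1.1-fold lower number from compound 2 to compound 4 (0.05 log units; that floor lies within the scatter), most likely again unreadable.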

Compound 4, half-maximal cytotoxic concentration: >= 146000 nM
Compound 4 gave a limit, no number (the forecaster's own chance of this, stated with the estimate: 70%); the middle value is on the limit's open side.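

In this assay compound 4 gives >= 146000 nM, a limit of the assay and not a number. Compound 2 also stands at a limit, so the step between compound 2 and compound 4 cannot be read. The compounds shown leave open whether replacing 4-methoxyphenyl with 2,4-dichlorophenyl changes the tolerated concentration at all.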